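From 4-acetamidophenoxy to benzyl on the chain

A few compounds are considered here, and "the series" means these few. Any claim that something is new, unique, unknown or untested is made for them only; others in the source may bear on it.

Values measured in a functional assay (aorta) with Oryctolagus cuniculus as the target (on this read-out higher numbers stand for weaker binding and lower numbers for tighter binding), are these:

- compound 1 `Fc1ccc(C(c2ccc(F)cc2)C2CCN(CCCOc3ccc(Cl)cc3)CC2)cc1` gives 2 nM 
- compound 2 `Nc1ccc(OCCCN2CCC(C(c3ccc(F)cc3)c3ccc(F)cc3)CC2)cc1` gives 31.6 nM 
- compound 3 `CC(=O)Nc1ccc(OCCCN2CCC(C(c3ccc(F)cc3)c3ccc(F)cc3)CC2)cc1` gives 12.6 nM 

Of these three, compound 3 stands second highest in this assay with compound 2 above it and compound 1 below it. Compound 4 `Fc1ccc(C(c2ccc(F)cc2)C2CCN(CCCCc3ccccc3)CC2)cc1` carries benzyl in place of 4-acetamidophenoxy on a saturated chain carbon, three bonds along the chain from an amine nitrogen in a ring. For the measured compounds named here, no measured step makes this exact change, since all three alter only the substituent on the aromatic ring. They still offer a guide. The number rises with amino, a 16-fold higher number from compound 1 to compound 2 (1.20 log units; beyond the scatter) and also rises with acetamido, a 6.3-fold higher number from compound 1 to compound 3 (0.80 log units; beyond the scatter) while acetylation of the amine recovers part of the loss, a 2.5-fold lower number from compound 2 to compound 3 (0.40 log units; beyond the scatter) and these are large to modest moves. Compound 4 no longer has the acetamido group, so a modest step to a lower number is expected. The expected move is a 2.5-fold lower number from compound 3 to compound 4 (0.40 log units; beyond the scatter) as an estimate only. The estimate for compound 4 is 5 nM with an expected range of 1.2 nM to 20 nM on this read-out.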

Compound 4, dissociation constant: 2.51 nM
The estimate for compound 4 lay 2.0-fold (0.30 log units) above the measured number; low and high end bracket the measured number.
By their numbers in this assay, from the lowest: compounds 1 and 4 (each within the scatter of the next); then compound 3; then compound 2.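

The earlier steps shown here altered only the substituent on the aromatic ring, whereas replacing 4-acetamidophenoxy with benzyl on a saturated chain carbon, three bonds along the chain from an amine nitrogen in a ring, gives a 5.0-fold lower number from compound 3 to compound 4 (0.70 log units; beyond the scatter) in this assay. Against the 4-aminophenoxy group, the same position tolerates benzyl with a larger gain, a 13-fold lower number from compound 2 to compound 4 (1.10 log units; beyond the scatter). Against 4-chlorophenoxy, benzyl gives a 1.3-fold higher number from compound 1 to compound 4 (0.10 log units; within the scatter), so in this set a low number requires neither the chloro substituent nor the oxygen of the phenoxy group.

From the compounds shown here alone, whether a longer chain, or a chloro or carboxylic acid group on the ring of benzyl, would keep the number this low remains open. Nothing available explains any of these steps.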